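The source may report more compounds than this note shows. Statements on the series, on what has been measured and on what is new or still open speak of the compounds shown alone.

Measured so far in an ADME assay on Vero cells (Chlorocebus sabaeus) for cytotoxicity, read by resazurin assay, with a stated time of 72 h; on this read-out lower numbers stand for stronger inhibition and higher numbers for weaker inhibition 
compound 1 `Cc1ccc(C(=O)CCN2CCN(c3ccc(Cl)cc3)CC2)cc1` gives 184000 nM 
compound 2 `O=C(CCN1CCN(c2ccc(Cl)cc2)CC1)c1ccc(Br)cc1` gives 52100 nM 
compound 3 `O=C(CCN1CCN(c2ccc(C(F)(F)F)cc2)CC1)c1ccc(F)c(F)c1` gives 14000 nM 

Of these three, compound 3 holds the lowest number in this assay while compound 2 stands nearest to it and compound 1 furthest. The next compound is compound 4 `O=C(CCN1CCN(c2ccc(Cl)cc2)CC1)c1ccc(F)c(F)c1` and it differs from compound 3 in a single place, with chloro in place of trifluoromethyl on an aromatic carbon.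

Going by the values given here, no measured step makes this exact swap. Among the compounds with values here, the one measured step between compounds differing in one place is a 3.5-fold lower number from compound 1 to compound 2 (0.55 log units; beyond the scatter) and it lies at a different place in the molecule. Within the data shown here, it shows only that a single small swap can move the number beyond the scatter. Compound 4 gains the chloro that compound 2 already carries, and compound 2 gives 52100 nM in this assay, a higher number than compound 3 shows. However, compound 2 also differs from compound 3 at a second place, so that gap cannot be assigned to the chloro alone.

A modest rise is therefore expected, and the estimated change is a 2.5-fold higher number from compound 3 to compound 4 (0.40 log units; beyond the scatter) in size. For compound 4 the estimated value is 35000 nM with an expected range from 13000 nM to 90000 nM in this measurement.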

Compound 4, half-maximal inhibitory concentration: 86200 nM
For compound 4 the middle estimate is 2.5-fold (0.39 log units) below the measured one; measured number inside the range.
By their numbers in this assay, from the lowest: compound 3; then compounds 2 and 4 (each within the scatter of the next); then compound 1.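

In this assay chloro in place of trifluoromethyl on the aromatic carbon para to a large group gives a 6.2-fold higher number from compound 3 to compound 4 (0.79 log units; beyond the scatter) and so shows that this position, untouched by the earlier step, can move the number beyond the scatter. With chloro held in that place, the group on the carbonyl carbon gives a mixed picture: 3,4-difluorophenyl in place of 4-bromophenyl gives a 1.7-fold higher number from compound 2 to compound 4 (0.22 log units; within the scatter) and stays within the scatter, while 3,4-difluorophenyl in place of 4-methylphenyl gives a 2.1-fold lower number from compound 1 to compound 4 (0.33 log units; beyond the scatter) and lies modestly beyond it. No measured information accompanies these numbers to explain any of these shifts.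

Only two groups are shown at this position, so it remains open whether a methoxy group, a nitrile or an amine there would give a number closer to that of chloro or of trifluoromethyl. Going by these compounds alone, the swap is also seen only with 3,4-difluorophenyl on the carbonyl carbon, so it remains open whether it would give a step of similar size with 4-bromophenyl or 4-methylphenyl in that place.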